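The compounds below may be only part of what the source reports. "The series", "measured", "known", "first", "only" and "open" are said of these compounds alone.

Measured so far in a functional assay on G-361 cells (Homo sapiens) for antiproliferative activity, with a stated time of 72 h; a lower number here means a stronger inhibitor, a higher number a weaker inhibitor:

compound 1, `OC[C@H]1O[C@@H](n2cnc3c(NCc4cccc(F)c4)ncnc32)[C@H](O)[C@@H]1O`: > 166000 nM
compound 2, `OC[C@H]1O[C@@H](n2cnc3c(NCc4ccc(Cl)cc4)ncnc32)[C@H](O)[C@@H]1O`: > 166000 nM
compound 3, `OC[C@H]1O[C@@H](n2cnc3c(NCc4ccc(Cl)c(Cl)c4)ncnc32)[C@H](O)[C@@H]1O`: 145000 nM

The value of compound 1 is a limit of this assay, not a number. The value of compound 2 is likewise a limit. Compound 3 is the only one of the three with a number, and the other two sit at the limit of > 166000 nM in this assay, at which 2 of the 3 values shown sit, so every step toward compound 3 only carries a floor: an at least 1.1-fold lower number from compound 1 to compound 3 (0.05 log units; that floor lies within the scatter) and an at least 1.1-fold lower number from compound 2 to compound 3 (0.05 log units; that floor lies within the scatter), both of which lie within the scatter, while a step that the two limits leave unreadable from compound 1 to compound 2 cannot be read at all. Compound 4, `COc1cccc(CNc2ncnc3c2ncn3[C@@H]2O[C@H](CO)[C@@H](O)[C@H]2O)c1O`, has not yet been measured. It differs from compound 3 in one place: 2-hydroxy-3-methoxyphenyl in place of 3,4-dichlorophenyl on a saturated chain carbon bound to a nitrogen on an aromatic ring. Among the measured steps, the two that change the ring on that carbon are the ones that bear on this change, and neither reached beyond the scatter. Compound 4 is therefore expected to show no step beyond the scatter, a 1.0-fold higher number from compound 3 to compound 4 (0.01 log units; within the scatter), and may well return only a limit. The estimate for compound 4 is 150000 nM, within 50000 nM to 400000 nM.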

Compound 4, half-maximal inhibitory concentration: 148000 nM
For compound 4 the middle estimate is 1.0-fold (0.01 log units) above the measured one; the range from low to high includes it.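

In this assay, the ring on the saturated chain carbon bound to a nitrogen on an aromatic ring can be exchanged for a very different one with no change beyond the scatter: a 1.0-fold higher number from compound 3 to compound 4 (0.01 log units; within the scatter). The earlier compounds shown here carried only halogens on this ring, whereas 2-hydroxy-3-methoxyphenyl brings in oxygen atoms, with a hydrogen-bond donor and acceptors that 3,4-dichlorophenyl lacks. The other two steps give only floors, an at least 1.1-fold lower number from compound 2 to compound 4 (0.04 log units; that floor lies within the scatter) and an at least 1.1-fold lower number from compound 1 to compound 4 (0.04 log units; that floor lies within the scatter), so they do not set compound 4 apart from the two compounds that returned a limit: the limit of > 166000 nM in this assay, at which 2 of the 4 values shown sit.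

Still open, as far as these compounds go, is whether any ring at this place can move the number beyond the scatter. An amine or a carboxylic acid on the ring, or a longer chain in place of that chain carbon, would test this.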